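The source may report more compounds than this note shows. Statements on the series, on what has been measured and on what is new or still open speak of the compounds shown alone.

Within the data shown here, in a functional assay on HEL cells (Homo sapiens) (on this read-out lower numbers stand for higher toxicity in this test and higher numbers for lower toxicity in this test), compound 1 (`CCCCCCCCCCc1cc2cn(COCCO)c(O)nc-2n1`) gives 32000 nM and so holds the only actual number among the three compounds measured. Compound 2 (`CCCCCCCC#Cc1cc2cn(COCCO)c(=O)nc2o1`) gives > 50000 nM which is a limit of the assay and not a number. Compound 3 (`CCCCC#Cc1cc2cn(COCCO)c(=O)nc2o1`) gives > 50000 nM which is likewise a limit.

Compound 4 (`CCCCCc1cc2cn(COCCO)c(O)nc-2n1`) has not been measured yet. It differs from compound 1 in one place: hydrogen in place of pentyl on a saturated chain carbon, five bonds along the chain from an aromatic carbon in words, hydrogen in place of pentyl on a saturated chain carbon, five bonds along the chain from an aromatic carbon.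

The nearest measured comparison is also a shortening of a chain, and it is a step that the two limits leave unreadable from compound 2 to compound 3 so it offers no size to carry across. With > 50000 nM as its limit, compound 3 shows only that a shorter chain need not bring a readable value in this assay on this evidence.

For compound 4 no step beyond the usual scatter is therefore expected, though it may lean towards lower toxicity, and the result may be reported only as a limit. The expected change is a 1.4-fold higher number from compound 1 to compound 4 (0.15 log units; within the scatter) at the estimated size. For compound 4 the estimate is 45000 nM with an expected range from 25000 nM to 80000 nM in this test.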

Compound 4, half-maximal cytotoxic concentration: > 200000 nM
Compound 4 gave a limit, no number; the forecaster's own chance of this, stated with the estimate: 60%; middle value at least 4.4-fold (0.64 log units) from the limit.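

In this assay, hydrogen in place of pentyl on a saturated chain carbon, five bonds along the chain from an aromatic carbon, gives an at least 6.2-fold higher number from compound 1 to compound 4 (0.79 log units; beyond the scatter), so on this core the shorter chain goes with clearly lower toxicity in this test. The earlier pair could not show this: the step between compound 2 and compound 3 cannot be read, since both ends are limits, whereas compound 1 has a real number to start from. Even so, the new step gives only a minimum size, and its true size remains unknown, as compound 4 also ends in a limit and not a number: the limit of > 200000 nM in this assay, at which 1 of the 4 values shown sits.

This single pair cannot show whether toxicity falls gradually or abruptly as the chain shortens, and an octyl chain at this place, or a chain longer than that of compound 1, would help to settle the question. It also remains open how this test would respond to a chain carrying an amine or a carboxylic acid, as neither group appears among these compounds.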